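Methylamino in place of methoxy on the shared core

The source may report more compounds than this note shows. Statements on the series, on what has been measured and on what is new or still open speak of the compounds shown alone.

In a functional assay on HCT-116 cells (Homo sapiens) for antiproliferative activity, read by MTT assay, with a stated time of 48 h (on this read-out higher numbers stand for weaker inhibition and lower numbers for stronger inhibition), compound 1 `CCCCCCCCC(CCO)n1cnc2c(Cl)ncnc21` gives 1650 nM. Compound 2 `CCCCCCCCC(CCO)n1cnc2c(OC)ncnc21` gives 12800 nM, the higher of the two numbers. Compound 3 `CCCCCCCCC(CCO)n1cnc2c(NC)ncnc21` differs from it as follows: methylamino in place of methoxy on an aromatic carbon. Among the measured compounds shown here, the one measured step on that aromatic carbon is a 7.8-fold higher number from compound 1 to compound 2 (0.89 log units; beyond the scatter). For the measured compounds named here, it starts from chloro, so it bears only indirectly, and no measured step involves methylamino. In this assay no change beyond the scatter is expected, and no firm direction. The estimated step is a 1.3-fold lower number from compound 2 to compound 3 (0.11 log units; within the scatter). For compound 3 the expected value is 10000 nM, with an estimated range of 3500 nM to 30000 nM.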

Compound 3, half-maximal inhibitory concentration: 3730 nM
For compound 3 the middle estimate is 2.7-fold (0.43 log units) above the measured one; low and high end bracket the measured number.
By their numbers in this assay, from the lowest: compound 1; then compound 3; then compound 2.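

In this assay, the aromatic carbon does not respond alike to all replacements of chloro: methylamino gives a clear gain over methoxy (a 3.4-fold lower number from compound 2 to compound 3 (0.54 log units; beyond the scatter)). Chloro still gives the lowest number of the three, with methylamino only partly closing the gap (a 2.3-fold higher number from compound 1 to compound 3 (0.35 log units; beyond the scatter)). Nothing available explains this order. Open, on these data alone, is how an unsubstituted amine, dimethylamino or ethoxy would rank at this aromatic carbon. Also open, as far as these compounds go, is whether the same order holds with a shorter chain on the shared core.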